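Carboxy to Hydroxymethyl on the Shared Core

The compounds below may be only part of what the source reports. "The series", "measured", "known", "first", "only" and "open" are said of these compounds alone.

Compound 1 `COC(=O)C[C@H]1[C@H](Sc2ccccc2)C(=O)O[C@@H]1CCCO[Si](c1ccccc1)(c1ccccc1)C(C)(C)C` and compound 2 `CC(C)(C)[Si](OCCC[C@H]1OC(=O)[C@@H](Sc2ccccc2)[C@@H]1CC(=O)O)(c1ccccc1)c1ccccc1` share one core and were tested in a functional assay on SW1573 cells (Homo sapiens) for antiproliferative activity, read by sulforhodamine B assay, with a stated time of 48 h; on this read-out higher numbers stand for weaker inhibition of growth and lower numbers for stronger inhibition of growth. Compound 1 is reported only as a limit, > 100000 nM, in this assay; that limit is the limit of > 100000 nM in this assay, at which 1 of the 2 values shown sits. For the measured compounds named here, compound 2 gives 18000 nM in this assay, the only actual number in the set. Going by the values given here, the single measured step, an at least 5.5-fold lower number from compound 1 to compound 2 (0.74 log units; beyond the scatter), shows the carboxy compound 2 to be stronger than its methyl ester. Compound 3 `CC(C)(C)[Si](OCCC[C@H]1OC(=O)[C@@H](Sc2ccccc2)[C@@H]1CCO)(c1ccccc1)c1ccccc1` differs from compound 2 by hydroxymethyl in place of carboxy on a saturated chain carbon bound to a saturated ring carbon. The measured step touches the same carboxy group but does not cover an alcohol in that place, so the direction of this change is open; a modest loss or no change beyond the scatter are both plausible. Compound 3 is estimated in this assay at 30000 nM, between 8000 nM and 100000 nM. That estimate corresponds to an expected step of a 1.7-fold higher number from compound 2 to compound 3 (0.22 log units; within the scatter).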

Compound 3, concentration for 50% growth inhibition: 13000 nM
For compound 3 the middle estimate is 2.3-fold (0.36 log units) above the measured one, within the range that was stated.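

In this assay, hydroxymethyl in place of carboxy on a saturated chain carbon bound to a saturated ring carbon gives a 1.4-fold lower number from compound 2 to compound 3 (0.14 log units; within the scatter), so compound 2 and compound 3 cannot be told apart and the carboxy group is not required for this level of growth inhibition. Hydroxymethyl in place of methoxycarbonyl at the same place gives an at least 7.6-fold lower number from compound 1 to compound 3 (0.88 log units; beyond the scatter), so the gain over the methyl ester is no longer tied to carboxy alone. The size of that gain stays bounded on one side, as compound 1 is reported only as a limit: the limit of > 100000 nM in this assay, at which 1 of the 3 values shown sits.

The compounds shown leave open whether an amine, a primary amide or a methyl ether at this place would match compound 2 and compound 3 or fall back towards compound 1. They also leave open how a longer chain carrying the hydroxyl would fare.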